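The source may report more compounds than this note shows. Statements on the series, on what has been measured and on what is new or still open speak of the compounds shown alone.

Working notes on the series.

The series is followed in a functional assay on HeLa cells (Homo sapiens) for inhibition, read by MTT assay, with a stated time of 48 h; a higher number here means a weaker inhibitor, a lower number a stronger inhibitor. Compound 1, `COc1cccc(-n2cc(NC(=O)c3cccc(NS(=O)(=O)c4ccccc4)c3)cn2)c1`, gives 26200 nM in this assay. Compound 2, `O=C(Nc1cnn(-c2ccccc2)c1)c1ccc(NS(=O)(=O)c2ccccc2)cc1`, gives 37100 nM in this assay. The two numbers lie within the usual scatter of each other, so compound 2 does not stand apart from compound 1 on what has been measured; both sit in the weak range of this assay.

Compound 3, `COc1ccc(-n2cc(NC(=O)c3ccc(NS(=O)(=O)c4ccccc4)cc3)cn2)cc1`, has not been measured in this assay. It differs from compound 2 in one place: methoxy in place of hydrogen on an aromatic carbon. Among the measured compounds shown here, no pair of measured compounds isolates this change, so there is no measured step to lean on. In the absence of such a step, and with the two measured compounds sitting close together, the working expectation is that the step from compound 2 to compound 3 stays small, with no direction that the data would support beyond the scatter; the expected step is a 1.2-fold lower number from compound 2 to compound 3 (0.09 log units; within the scatter). The estimate for compound 3 in this assay is accordingly 30000 nM, with a range from 12000 nM to 80000 nM.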

Compound 3, half-maximal inhibitory concentration: 47200 nM
Compound 3: the middle estimate sits 1.6-fold (0.20 log units) below what was measured; the range from low to high includes it.
By their numbers in this assay, from the lowest: compounds 1, 2 and 3 (each within the scatter of the next).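

Phenyl to 4-methoxyphenyl is the first change at this position with measured values at both ends, and the step is a 1.3-fold higher number from compound 2 to compound 3 (0.10 log units; within the scatter) in this assay. Methoxy in place of hydrogen on this aromatic carbon, para to a large group, therefore does not separate compound 3 from compound 2, and on this single pair the position shows no sensitivity to the change that can be told from the scatter of the assay. No measurement in hand bears on why the step is this size.

Going by these compounds, it remains open whether an amine or a carboxylic acid in place of the same hydrogen, or a longer chain such as ethoxy or butoxy in place of methoxy, would give a step beyond the scatter. On these data alone, compound 1 differs from compound 3 in more than one place, so the pair gives no reading of this position, and whether the methoxy step would hold on the core of compound 1 is also open.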